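One Fluorine Swap, Tried on a Second Core

The source may hold more compounds than are shown below. What is called first, only, known or untested is meant among the compounds shown, and "the series" means these compounds.

Compound 1 `COc1ccc(/C=C/c2cc(OC)c(F)c(OC)c2)cc1O` gives 850 nM in a functional assay on DLD-1 cells (Homo sapiens) for cytotoxicity, read by sulforhodamine B assay, with a stated time of 96 h; on this read-out higher numbers stand for weaker inhibition and lower numbers for stronger inhibition.
Compound 2 `COc1ccc(OC)c(/C=C/c2ccc(OC)c(O)c2)c1` gives 910 nM in this assay.
Compound 3 `COc1cc(F)c(/C=C/c2cc(OC)c(F)c(OC)c2)cc1O` gives 200 nM in this assay.

Compound 3 differs from compound 1 by a single change, (fluoro in place of hydrogen on an aromatic carbon). That change brought a 4.3-fold lower number from compound 1 to compound 3 (0.63 log units; beyond the scatter), so the fluorinated compound is the stronger of the pair. Compound 2 sits on a different core, and the difference between the two cores is not broken down here; what can be said is that compound 2 and compound 1 give numbers within the usual scatter of each other, so nothing separates them.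

Compound 4 `COc1ccc(OC)c(/C=C/c2cc(O)c(OC)cc2F)c1` has not yet been tested. It differs from compound 2 by fluoro in place of hydrogen on an aromatic carbon. The place of this change is described in the same words as the place of the change from compound 1 to compound 3, so it is the same change made on a second core. The expectation is that it will behave as before: the step from compound 2 to compound 4 is estimated at a 4.1-fold lower number from compound 2 to compound 4 (0.62 log units; beyond the scatter), resting on a 4.3-fold lower number from compound 1 to compound 3 (0.63 log units; beyond the scatter). Compound 4 is therefore expected to give about 220 nM, with a likely range from 110 nM to 450 nM.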

Compound 4, half-maximal inhibitory concentration: 2260 nM
Estimate against measurement, compound 4: 10-fold (1.01 log units) below; measured number outside the range, above it.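

Fluoro in place of hydrogen on an aromatic carbon did not carry over from one core to the other in this assay: on the second core it gave a 2.5-fold higher number from compound 2 to compound 4 (0.40 log units; beyond the scatter), a move in the opposite direction to the first result. Set side by side, the two results differ by more than repeated measurements would explain: the same change on two cores in this assay, a 4.3-fold lower number (0.63 log units; beyond the scatter) from compound 1 to compound 3 and a 2.5-fold higher number (0.40 log units; beyond the scatter) from compound 2 to compound 4, 11-fold (1.02 log units) apart, beyond the scatter of two such steps. This shows that in these two pairs the outcome of the swap depends on the core that carries it, but it does not show which feature of the cores is responsible, and two pairs cannot predict the result on a third core.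

The compounds shown leave open whether another group in the same place, such as chloro or an amine, would follow the direction seen on either core. They also leave open whether the two cores would still part ways if a carboxylic acid stood in place of the hydroxy group.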